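Triazolylmethyl spirooxindole series: aryl swaps at the triazole nitrogen

The source may report more compounds than this note shows. Statements on the series, on what has been measured and on what is new or still open speak of the compounds shown alone.

Compound 1 `N#CC1=C(N)Oc2c(N)cc3nc4ccccc4nc3c2C12C(=O)N(Cc1cnnn1-c1cccc(Br)c1)c1ccccc12` carries a 3-bromophenyl on the triazole nitrogen. In a functional assay on MCF7 cells (Homo sapiens) for antiproliferative activity, read by MTT assay, with a stated time of 48 h (a lower number here means a stronger inhibitor, a higher number a weaker inhibitor), compound 1 gives only a limit of the assay, > 50000 nM. Compound 2 `CCOc1ccccc1-n1nncc1CN1C(=O)C2(C(C#N)=C(N)Oc3c(N)cc4nc5ccccc5nc4c32)c2ccccc21` is the 2-ethoxyphenyl analogue; in this assay compound 2 likewise gives only a limit, > 50000 nM. Compound 3 `CCc1cccc(CC)c1-n1nncc1CN1C(=O)C2(C(C#N)=C(N)Oc3c(N)cc4nc5ccccc5nc4c32)c2ccccc21`, with a 2,6-diethylphenyl at the same nitrogen, gives in this assay only a limit too, > 50000 nM. Since all three values sit at the limit of > 50000 nM in this assay, at which 3 of the 3 values shown sit, the measured steps a step that the two limits leave unreadable from compound 1 to compound 2, a step that the two limits leave unreadable from compound 1 to compound 3 and a step that the two limits leave unreadable from compound 2 to compound 3 cannot be read in size or direction; compound 3 therefore stands nowhere distinguishable from compound 1 and compound 2.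

Compound 4 `N#CC1=C(N)Oc2c(N)cc3nc4ccccc4nc3c2C12C(=O)N(Cc1cnnn1-c1ccc(Cl)cc1[N+](=O)[O-])c1ccccc12` is the next aryl swap at the same position: 4-chloro-2-nitrophenyl in place of 2,6-diethylphenyl on an aromatic nitrogen. Within the data shown here, none of the measured steps bears on it, as each is unreadable; what they do show is that three different aryl groups at this nitrogen have all left the series without measurable activity in this assay. For compound 4 the expectation is therefore a step that the limit leaves unreadable from compound 3 to compound 4, that is, no readable change from compound 3, and the estimated value for compound 4 is 60000 nM, with a range from 20000 nM to 200000 nM, most likely reported again as a limit.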

Compound 4, half-maximal inhibitory concentration: > 50000 nM
Compound 4 gave a limit, no number (the forecaster's own chance of this, stated with the estimate: 80%); the middle value does not contradict the limit.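

Compound 4 also gives only a limit in this assay, so its steps from compound 1, compound 2 and compound 3 cannot be read in size or direction: the limit of > 50000 nM in this assay, at which 4 of the 4 values shown sit.

The compounds shown leave open whether any aryl group at this nitrogen, or any change elsewhere on the shared core, gives a measurable value in this assay.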